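The source may hold more compounds than are shown below. What is called first, only, known or untested is meant among the compounds shown, and "the series" means these compounds.

Measured so far:
- compound 1 `COC(CCn1cnc2c(NCc3ccc(C(=O)Nc4ccccc4N)cc3)nc(Cl)nc21)OC`: 11.9%
- compound 2 `CCCCn1cnc2c(NCc3ccc(C(=O)Nc4ccccc4N)cc3)nc(Cl)nc21`: 40.9%

Both were tested in a functional assay on HCT-116 cells (Homo sapiens) for antiproliferative activity, read by CCK-8 assay, with a stated time of 72 h, tested at 8 uM; on this read-out higher numbers stand for a stronger effect at the one concentration tested and lower numbers for a weaker effect. Among the measured compounds shown here, compound 2 gives the higher of the two numbers, with compound 1 the nearer and only neighbour, and the step of a number 29 percentage points higher from compound 1 to compound 2 (beyond the scatter) is the only measured step available. Compound 3 `Nc1ccccc1NC(=O)c1ccc(CNc2nc(Cl)nc3c2ncn3C2CCCC2)cc1` has not yet been measured. It differs from compound 2 in one place: cyclopentyl in place of butyl on an aromatic nitrogen. For the measured compounds named here, the one measured step changed a different part of the same chain, swapping a branched group for a plain one, so it bears on this change only loosely: it shows that altering the group on that aromatic nitrogen can shift the read-out by a modest amount, but it does not say in which direction a ring in place of a chain would move it. Going by the values given here, with no closer precedent, the expected step of a number 4.1 percentage points higher from compound 2 to compound 3 (within the scatter) is small, and the estimate for compound 3 in this assay is 45%, within a range from 25% to 65%.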

Compound 3, a percentage reported as inhibition, at one concentration (the size of the read-out at that concentration, not a potency): 80.6%
Beside the measured number, compound 3's estimate is 35.6 percentage points below it; the whole stated range lies below it.
By their numbers in this assay, from the lowest: compound 1; then compound 2; then compound 3.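

In this assay, the group on the aromatic nitrogen proves to matter a great deal even when the change is small on paper: cyclopentyl in place of butyl gives a number 39.7 percentage points higher from compound 2 to compound 3 (beyond the scatter), although neither group carries a hydrogen-bond donor or acceptor. Cyclopentyl in place of 3,3-dimethoxypropyl on the same nitrogen gives a number 68.7 percentage points higher from compound 1 to compound 3 (beyond the scatter), so these three compounds place the cyclopentyl ring at the top and show that this position can carry most of the spread seen here. Why the ring outperforms both open chains cannot be told, as no measurement here speaks to the cause of the difference.

On these data alone, whether the ring itself counts, or simply the shape and size of the group, stays open, and a cyclobutyl or cyclohexyl ring or a branched isopropyl group on this nitrogen would help to separate those readings. As far as these compounds go, it is also open whether a ring bearing an amine or a hydroxyl group would keep this level of inhibition, and whether the ranking would hold at other concentrations, since a single concentration gives no potency.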